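The compounds below may be only part of what the source reports. "The series", "measured", "known", "first", "only" and "open" are said of these compounds alone.

Measured so far in a functional assay on HepG2 cells (Homo sapiens) for antiproliferative activity, read by CCK-8 assay, with a stated time of 72 h, tested at 2 uM; a lower number here means a weaker effect, a higher number a stronger effect of the compound at the concentration tested:
compound 1 `Nc1ccccc1NC(=O)c1ccc(Cn2cnc3c(Nc4ccccc4)nc(Cl)nc32)cc1` gives 49.6%
compound 2 `Nc1ccccc1NC(=O)c1ccc(CNc2nc(Cl)nc3c2ncn3Cc2ccccc2)cc1` gives 5.01%
compound 3 `CCC(C)n1cnc2c(NCc3ccc(C(=O)Nc4ccccc4N)cc3)nc(Cl)nc21` gives 45%

Compound 1 carries the highest of the three numbers; compound 3 sits nearest, within the scatter, and compound 2 lies furthest away, beyond it. Within the data shown here, the one step available, a number 40 percentage points higher from compound 2 to compound 3 (beyond the scatter), concerns the substituent on the ring nitrogen of the shared core, not the amino nitrogen, so it bears only indirectly on the change now at hand.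

Compound 4 `Nc1ccccc1NC(=O)c1ccc(Cn2cnc3c(NCc4ccccc4)nc(Cl)nc32)cc1` differs from compound 1 by benzyl in place of phenyl on a nitrogen on an aromatic ring. Compound 3 shows that a benzylamino at this position is compatible with a number close to that of compound 1, while compound 2, which carries its benzyl on the ring nitrogen instead, gives 5.01%. The expected outcome is therefore a step of a number 11.6 percentage points lower from compound 1 to compound 4 (beyond the scatter), most likely within the scatter or a modest fall. Compound 4 is estimated at 38%, within a range of 15% to 60% in this assay.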

Compound 4, a percentage reported as inhibition, at one concentration (the size of the read-out at that concentration, not a potency): 7.55%
Estimate against measurement, compound 4: 30.5 percentage points above, outside the stated range (below it).
By their numbers in this assay, from the lowest: compounds 2 and 4 (each within the scatter of the next); then compounds 3 and 1 (each within the scatter of the next).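

In this assay, going from anilino to benzylamino on the shared core gives a number 42.1 percentage points lower from compound 1 to compound 4 (beyond the scatter), so this nitrogen on an aromatic ring does not accept the change without a large loss of inhibition at the concentration tested. Among these compounds, this is the first step at this nitrogen, as the only earlier step concerned the substituent on the ring nitrogen, and it shows that the read-out here depends on whether phenyl or benzyl is attached. No measurement available here bears on why the benzyl group gives this result.

From the compounds shown here alone, whether the loss continues with a longer chain such as phenethyl, or also appears with a non-aromatic group such as cyclohexyl, remains open. Also open, going by these compounds, is whether substituents on the phenyl ring of the anilino group, such as fluoro or methoxy, keep the inhibition of compound 1.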